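The source may report more compounds than this note shows. Statements on the series, on what has been measured and on what is new or still open speak of the compounds shown alone.

Compound 2 `COc1ccc2c(=O)c(/C=C/C(=O)NCc3ccccc3)coc2c1` carries the shared core with a benzyl group on an amide-type nitrogen. In a functional assay (QGY7701 cells, Homo sapiens) for inhibition, read by MTT assay, with a stated time of 48 h (a higher number here means a weaker inhibitor, a lower number a stronger inhibitor), compound 2 gives > 100000 nM, which is a limit of the assay and not a number. Compound 1 `COc1ccc2c(=O)c(/C=C/C(=O)Nc3cccc(Cl)c3)coc2c1` differs from it only by a 3-chlorophenyl group in that place. In this assay compound 1 gives > 100000 nM, again a limit rather than a number. The step that the two limits leave unreadable from compound 1 to compound 2 is therefore unreadable. Compound 3 `COc1ccc2c(=O)c(/C=C/C(=O)Nc3ccccc3Cl)coc2c1` has not been measured; it changes compound 2 by 2-chlorophenyl in place of benzyl on an amide-type nitrogen. Among the compounds with values here, no measured step bears directly on this change, and because the limit of > 100000 nM in this assay, at which 2 of the 2 values shown sit, both known values sit at the same limit, nothing points to a step of any size or direction in this assay. The expected step of a number no higher from compound 2 to compound 3 (the limit leaves the size open) is thus none beyond the scatter, most likely reported once more as a limit. For compound 3 the estimate is 100000 nM, within 30000 nM to 300000 nM.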

Compound 3, half-maximal inhibitory concentration: 23000 nM
Beside the measured number, compound 3's estimate is 4.3-fold (0.64 log units) above it; measured number outside the range, below it.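

In this assay, within the data shown here, the group on the amide-type nitrogen can decide whether a measurable number appears at all, and compound 3 is the first compound here to give a number rather than a limit. Putting 2-chlorophenyl in place of benzyl brings an at least 4.3-fold lower number from compound 2 to compound 3 (0.63 log units; beyond the scatter), while 2-chlorophenyl in place of 3-chlorophenyl brings an at least 4.3-fold lower number from compound 1 to compound 3 (0.63 log units; beyond the scatter), so carrying a chlorine is not enough by itself and its place on the ring counts. Both steps give only a minimum size, because each starts from a limit: the limit of > 100000 nM in this assay, at which 2 of the 3 values shown sit.

The compounds shown leave open whether chlorine itself is needed, which a 2-fluorophenyl, 2-methylphenyl or plain phenyl group would help to settle. They also leave open how a 2,6-dichlorophenyl group would read in this assay.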